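The source may report more compounds than this note shows. Statements on the series, on what has been measured and on what is new or still open speak of the compounds shown alone.

Compound 1 `N#Cc1c(N)nc(SCc2ccn[nH]2)c(C#N)c1-c1ccc(OCC2CC2)cc1` is the starting point for this step. In a functional assay on CHO cells for agonist activity at adenosine receptor A2b (Homo sapiens), read by AlphaScreen and cAMP accumulation (on this read-out higher numbers stand for an effect only at larger amounts of compound and lower numbers for an effect already at smaller amounts), compound 1 gives 84 nM, the second highest of the three numbers in hand. Compound 2 `N#Cc1c(N)nc(SCC(=O)NCO)c(C#N)c1-c1ccc(OCC2CC2)cc1` gives 182 nM in this assay, and compound 3 `N#Cc1c(N)nc(SCc2cccc(C(N)=O)c2)c(C#N)c1-c1ccc(OCC2CC2)cc1` gives 12.7 nM in this assay. The measured steps are a 2.2-fold higher number from compound 1 to compound 2 (0.34 log units; beyond the scatter), a 6.6-fold lower number from compound 1 to compound 3 (0.82 log units; beyond the scatter) and a 14-fold lower number from compound 2 to compound 3 (1.16 log units; beyond the scatter).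

Compound 4 `COC(=O)c1cccc(CSc2nc(N)c(C#N)c(-c3ccc(OCC4CC4)cc3)c2C#N)c1` has not been measured. Its difference from compound 1 is 3-(methoxycarbonyl)phenyl in place of 1H-pyrazol-5-yl on a saturated chain carbon bound to a sulfur. The step that bears on it most directly is a 6.6-fold lower number from compound 1 to compound 3 (0.82 log units; beyond the scatter), since 3-(methoxycarbonyl)phenyl is a close relative of 3-carbamoylphenyl, both being built on a six-membered aromatic ring of carbon only. The step to compound 2, a 2.2-fold higher number from compound 1 to compound 2 (0.34 log units; beyond the scatter), shows that the group at this position matters but does not speak to an ester. Compound 4 is expected to show a 3.4-fold lower number from compound 1 to compound 4 (0.53 log units; beyond the scatter), a lower number beyond the scatter that is expected to fall short of the full size of the carbamoyl step seen in a 6.6-fold lower number from compound 1 to compound 3 (0.82 log units; beyond the scatter). Compound 4 is estimated at 25 nM, with a range from 8 nM to 80 nM.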

Compound 4, half-maximal effective concentration: 347 nM
Beside the measured number, compound 4's estimate is 14-fold (1.14 log units) below it, outside the stated range (above it).
By their numbers in this assay, from the lowest: compound 3; then compound 1; then compounds 2 and 4 (each within the scatter of the next).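

The benzyl-type side chain alone does not carry the gain at this position: in this assay, methoxy in place of amino on a carbonyl carbon gives a 27-fold higher number from compound 3 to compound 4 (1.44 log units; beyond the scatter), the largest step in the set, so the outcome depends on the carbonyl substituent. Replacing 1H-pyrazol-5-yl with a six-membered aromatic ring of carbon only can therefore go either way, since a 4.1-fold higher number from compound 1 to compound 4 (0.62 log units; beyond the scatter) runs opposite to the step to compound 3, while a 1.9-fold higher number from compound 2 to compound 4 (0.28 log units; within the scatter) leaves compounds 2 and 4 unseparated. Nothing available here explains the sharp split between the amide and the ester.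

A methylcarbamoyl, a dimethylcarbamoyl or a carboxylic acid on the same ring would show how much of the amino group is needed. A plain benzyl group would give the baseline without any carbonyl substituent.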